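Working notes: from compound 2 to compound 3

The source may report more compounds than this note shows. Statements on the series, on what has been measured and on what is new or still open speak of the compounds shown alone.

Of the compounds shown here, two have been measured in an assay on HEK293 cells for positive allosteric modulation of metabotropic glutamate receptor 5 (Homo sapiens), read by FLIPR, with a stated time of 1 h; a higher number here means that more compound is needed for the effect, a lower number that less compound is needed. Compound 1 `COc1ccccc1C#Cc1nc2c(s1)C(=O)NCC2` gives only a limit there, > 10000 nM. Compound 2 `CC(C)CN1CCc2nc(C#Cc3ccccc3)sc2C1` likewise gives only a limit, > 10000 nM. Both readings sit at the limit of > 10000 nM in this assay, at which 2 of the 2 values shown sit, so compound 2 stands where every value shown stands, and no ordering can be drawn from them. Compound 3 `O=S(=O)(C1CC1)N1CCc2nc(C#Cc3ccccc3)sc2C1` differs from compound 2 by cyclopropylsulfonyl in place of isobutyl on an amine nitrogen in a ring. Among the compounds with values here, no measured pair shows what such a change does in this assay. The expected step is an at least 1.2-fold lower number from compound 2 to compound 3 (0.09 log units; that floor lies within the scatter), probably not beyond the scatter, with a real chance of another limit. Compound 3 is estimated at 8000 nM, between 2000 nM and 30000 nM.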

Compound 3, half-maximal effective concentration: > 10000 nM
Compound 3 ended at the assay's limit (the forecaster's own chance of this, stated with the estimate: 60%); middle value at least 1.2-fold (0.09 log units) from the limit.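

Compound 2 and compound 3 both give only a limit in this assay, so no step can be read between them: the limit of > 10000 nM in this assay, at which 3 of the 3 values shown sit.

The compounds shown leave open whether cyclopropylsulfonyl in place of isobutyl on an amine nitrogen in a ring changes the number at all.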